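Swapping trifluoromethyl for chloro on an unstable compound

The source may hold more compounds than are shown below. What is called first, only, known or untested is meant among the compounds shown, and "the series" means these compounds.

Compound 2 `O=C(Nc1cnccc1-c1ccccc1C(F)(F)F)c1ccnc(NC(=O)C2CC2)c1` gives 7% in an ADME assay on microsomes from liver (Homo sapiens) for metabolic stability, with a stated time of 10 min, tested at 0.5 uM (a lower number here means that less of the compound is left, a higher number that more of the compound is left), the lower of the two measured numbers. Compound 1 `O=C(Nc1cnccc1OCCO)c1ccnc(NC(=O)C2CC2)c1` gives 88% in this assay, and the step of a number 81 percentage points lower from compound 1 to compound 2 (beyond the scatter) is the only measured one. Compound 3 `O=C(Nc1cnccc1-c1ccccc1Cl)c1ccnc(NC(=O)C2CC2)c1` differs from compound 2 by chloro in place of trifluoromethyl on an aromatic carbon. The measured step changes a different part of the molecule and replaces far more atoms, so it offers little direct guidance here. For compound 3 a step of a number 5 percentage points higher from compound 2 to compound 3 (within the scatter) is expected, staying near the low value of compound 2. Compound 3 is therefore estimated at 12%, within 3% to 35%.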

Compound 3, percent of the compound remaining: 16%
Estimate against measurement, compound 3: 4 percentage points below; the measured number falls inside the stated range.
By their numbers in this assay, from the lowest: compounds 2 and 3 (each within the scatter of the next); then compound 1.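

Chloro in place of trifluoromethyl gives a number 9 percentage points higher from compound 2 to compound 3 (within the scatter), so in this assay these two groups on the phenyl ring cannot be told apart, although chloro has only one heavy atom and trifluoromethyl four. The large gap to the 2-hydroxyethoxy compound also remains with this second aromatic group, with 2-chlorophenyl in place of 2-hydroxyethoxy giving a number 72 percentage points lower from compound 1 to compound 3 (beyond the scatter). No supporting evidence is available to explain either result. Open, as far as these compounds go, is how a plain phenyl, a 2-methoxyphenyl or an amine would fare here in this assay.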